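The source may report more compounds than this note shows. Statements on the series, on what has been measured and on what is new or still open speak of the compounds shown alone.

The three measured compounds share one core; compound 1 `COc1cc(-c2nnc3n2NC(c2ccco2)C(C(=O)c2ccccc2C)S3)cc(OC)c1OC`, compound 2 `COc1cc(-c2nnc3n2NC(c2ccco2)C(C(=O)c2cccs2)S3)cc(OC)c1OC` and compound 3 `COc1cc(-c2nnc3n2NC(c2ccco2)C(C(=O)c2cccc4ccccc24)S3)cc(OC)c1OC` differ only in the aryl group on the carbonyl carbon. In a functional assay on HepG2 cells (Homo sapiens) for cytotoxicity, read by MTT assay, with a stated time of 48 h (a higher number here means a weaker inhibitor, a lower number a stronger inhibitor), compound 1 gives 63000 nM, compound 2 gives 64100 nM and compound 3 gives 33900 nM. Compound 3 sits at the low end of the three numbers, but a 1.9-fold lower number from compound 1 to compound 3 (0.27 log units; within the scatter) and a 1.9-fold lower number from compound 2 to compound 3 (0.28 log units; within the scatter) are both within the scatter, as is a 1.0-fold higher number from compound 1 to compound 2 (0.01 log units; within the scatter). Compound 4 `COc1cc(-c2nnc3n2NC(c2ccco2)C(C(=O)c2cccc(Br)c2)S3)cc(OC)c1OC` is not yet measured; it differs from compound 3 by 3-bromophenyl in place of naphthalen-1-yl on a carbonyl carbon. All three measured steps exchange the same aryl group on the carbonyl carbon and none leaves the scatter, so the change to compound 4 is expected to give a step within the scatter in this assay as well, if anything a small drift back toward the numbers of compound 1 and compound 2. The estimated step is a 1.4-fold higher number from compound 3 to compound 4 (0.15 log units; within the scatter). For compound 4 the expected value in this assay is 48000 nM, with a range from 24000 nM to 96000 nM.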

Compound 4, half-maximal inhibitory concentration: > 100000 nM
Compound 4 ended at the assay's limit (the forecaster's own chance of this, stated with the estimate: 10%); middle value at least 2.0-fold (0.31 log units) away from the limit.
By their numbers in this assay, from the lowest: compounds 3, 1 and 2 (each within the scatter of the next). At a limit, above all of these: compound 4.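

In this assay compound 4 gives a limit and not a number: the limit of > 100000 nM in this assay, at which 1 of the 4 values shown sits.

Even so, the position on the carbonyl carbon now shows a step beyond the scatter, an at least 2.9-fold higher number from compound 3 to compound 4 (0.46 log units; beyond the scatter), where the earlier exchanges among compounds 1, 2 and 3 all stayed within it. The other two steps, an at least 1.5-fold higher number from compound 2 to compound 4 (0.19 log units; that floor lies within the scatter) and an at least 1.5-fold higher number from compound 1 to compound 4 (0.20 log units; that floor lies within the scatter), have floors within the scatter, so only the exchange of naphthalen-1-yl for 3-bromophenyl is shown to matter, and compound 4 is not separated from compound 1 or compound 2.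

The compounds shown do not separate the loss of the second aromatic ring from the entry of bromine, since both change together in this step. From the compounds shown here alone, how an unsubstituted phenyl, or a phenyl carrying an amine or a carboxylic acid in place of the bromine, would read in this assay remains open.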